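Chloro Entering the Isobutoxy-Bearing Ring of Compound 1

A few compounds are considered here, and "the series" means these few. Any claim that something is new, unique, unknown or untested is made for them only; others in the source may bear on it.

Compound 1 `CC(C)COc1ccc(-c2cn(C)c3cc(C(=O)NS(=O)(=O)C4CC4)c(F)cc23)cn1` was examined in an ADME assay on microsomes from liver (Homo sapiens) for metabolic stability, with a stated time of 10 min, tested at 0.5 uM (a higher number here means that more of the compound is left, a lower number that less of the compound is left), where compound 1 gives 100%. A second compound, compound 2 `CC(C)COc1ncc(-c2nn(C)c3cc(C(=O)NS(C)(=O)=O)ccc23)cc1Cl`, was also run, and in this assay compound 2 gives 100%, so compound 1 stands level with compound 2 at the digits shown, the difference lying within the usual scatter. For the measured compounds named here, no step between two measured compounds is available to guide a prediction.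

The unmeasured compound 3 `CC(C)COc1ncc(-c2cn(C)c3cc(C(=O)NS(=O)(=O)C4CC4)c(F)cc23)cc1Cl` arises from compound 1 by one change, (chloro in place of hydrogen on an aromatic carbon), the chloro sitting ortho to an isobutoxy group and two atoms from the ring nitrogen. Since compound 1 already gives 100% in this assay, and the read-out cannot rise further, the step of a number 2 percentage points lower from compound 1 to compound 3 (within the scatter) is expected to show no change beyond the scatter. Compound 3 is therefore estimated at 98% in this assay, within a range from 85% to 100%.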

Compound 3, percent of the compound remaining: 100%
Compound 3: middle estimate off by 2 percentage points, on the low side, within the range that was stated.
By their numbers in this assay, from the lowest: compounds 1, 2 and 3 (each within the scatter of the next).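

Placing chloro on this aromatic carbon, ortho to an isobutoxy group and two atoms from the ring nitrogen, gives no change at the digits printed from compound 1 to compound 3 (within the scatter) in this assay, the first step among these compounds that can be read at this position. The position therefore takes chloro with no loss that this read-out can show, although compound 1 and compound 3 both stand at the top of the read-out, so a step upward could not appear here. Nothing measured here speaks to why the step is flat.

From the compounds shown here alone, whether this carbon would behave the same way with a methoxy group, a nitrile or an amine in place of chloro remains open. Also open, going by these compounds, is whether chloro would leave the value unchanged on a compound standing lower in this read-out.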